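Analgesic series: switching the ester side chain

The source may hold more compounds than are shown below. What is called first, only, known or untested is meant among the compounds shown, and "the series" means these compounds.

Measured compounds:
- compound 1 `O=C(CN(c1nc(Cl)nc2[nH]cnc12)C1CC1)N[C@@H](CO)C(=O)OCc1ccccc1`: 27.9%
- compound 2 `O=C(O)[C@@H]1CCCN1C(=O)CN(c1nc(Cl)nc2[nH]cnc12)C1CC1`: 7.29%
- compound 3 `N=C(N)NCCC[C@H](NC(=O)CN(c1nc(Cl)nc2[nH]cnc12)C1CC1)C(=O)O`: 7.19%

In a functional assay on the whole organism (Tail, strain ICR) with Mus musculus as the target, in the tail flick test, with a stated time of 150 min, at a dose of 25 umol/kg by the oral route (on this read-out lower numbers stand for a weaker effect and higher numbers for a stronger effect at the one dose given), compound 1 gives 27.9%, the highest of the three numbers. Compound 2 gives 7.29% and compound 3 gives 7.19%; both gaps to compound 1 are beyond the scatter, whereas compound 2 and compound 3 lie within the scatter of each other. Going by the values given here, compound 1 carries a benzyl ester, compound 2 and compound 3 a free acid; no step between compounds differing in one place is available, so no single change can be isolated from these values.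

Compound 4 `CC(C)[C@H](NC(=O)CN(c1nc(Cl)nc2[nH]cnc12)C1CC1)C(=O)OCc1ccccc1` keeps the benzyl ester of compound 1 and differs only as follows: isopropyl in place of hydroxymethyl on a saturated chain carbon bound to an amide-type nitrogen and a carbonyl carbon. Nothing measured tells how this change acts. Since the ester is retained, compound 4 is expected to stay near compound 1: the step of a number 2.1 percentage points higher from compound 1 to compound 4 (within the scatter) is expected to be small, likely within the scatter, with a wide band either way. Compound 4 is therefore estimated at 30%, between 10% and 55%.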

Compound 4, a percentage reported as activity, at one dose (the size of the read-out at that dose, not a potency): 17.9%
Estimate against measurement, compound 4: 12.1 percentage points above; low and high end bracket the measured number.
By their numbers in this assay, from the lowest: compounds 3 and 2 (each within the scatter of the next); then compounds 4 and 1 (each within the scatter of the next).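

In this assay, going by these compounds alone, isopropyl in place of hydroxymethyl on a saturated chain carbon bound to an amide-type nitrogen and a carbonyl carbon gives a number 10 percentage points lower from compound 1 to compound 4 (within the scatter), the only single-place comparison so far. With the benzyl ester kept, this position therefore takes isopropyl, which has no hydrogen-bond donor or acceptor, in place of hydroxymethyl, which has one of each, without a step beyond the scatter. Nothing available bears on how this change acts.

As far as these compounds go, whether the same tolerance holds when a free carboxylic acid replaces the benzyl ester remains open. A primary amine or a longer alkyl chain on this carbon would test how far the position extends beyond these two groups.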